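Benzimidazole 2-substituent series: from cyclohexyl to propyl

The source may hold more compounds than are shown below. What is called first, only, known or untested is meant among the compounds shown, and "the series" means these compounds.

Compound 3 `CCCCOC(=O)NS(=O)(=O)c1ccc(CCC)cc1-c1ccc(Cn2c(C3CCCCC3)nc3ccccc32)cc1` gives 130 nM in an assay on membranes from HEK293 cells for displacement of a labelled ligand from Type-2 angiotensin II receptor (Homo sapiens), read by radioligand binding (on this read-out higher numbers stand for weaker inhibition and lower numbers for stronger inhibition), the highest number of the three measured compounds. Compound 1 `CCCCOC(=O)NS(=O)(=O)c1ccc(CCC)cc1-c1ccc(Cn2c(C3CCCC3)nc3ccccc32)cc1` gives 35 nM, and compound 2 `CCCCOC(=O)NS(=O)(=O)c1ccc(CCC)cc1-c1ccc(Cn2c(Cc3ccccc3)nc3ccccc32)cc1` gives 15 nM. Both steps into compound 3 raise the number: a 3.7-fold higher number from compound 1 to compound 3 (0.57 log units; beyond the scatter) and an 8.7-fold higher number from compound 2 to compound 3 (0.94 log units; beyond the scatter). Compound 4 `CCCCOC(=O)NS(=O)(=O)c1ccc(CCC)cc1-c1ccc(Cn2c(CCC)nc3ccccc32)cc1` differs from compound 3 by propyl in place of cyclohexyl on an aromatic carbon. The two measured steps bear on this change, since each replaces a group at the same position, and both show that cyclohexyl gives the weakest binding of the three. A drop in the number, back toward the range of compound 1 and compound 2, is therefore expected in this assay. For compound 4 the estimate is 35 nM, with a range from 12 nM to 110 nM, meaning an expected step of a 3.7-fold lower number from compound 3 to compound 4 (0.57 log units; beyond the scatter).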

Compound 4, inhibition constant: 14 nM
Compound 4: the middle estimate sits 2.5-fold (0.40 log units) above what was measured; measured number inside the range.
By their numbers in this assay, from the lowest: compounds 4 and 2 (each within the scatter of the next); then compound 1; then compound 3.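

Having a ring or an open chain at this position does not by itself set the number: propyl gives a 9.3-fold lower number from compound 3 to compound 4 (0.97 log units; beyond the scatter) and a 2.5-fold lower number from compound 1 to compound 4 (0.40 log units; beyond the scatter) against the two saturated rings. Against benzyl the step is a 1.1-fold lower number from compound 2 to compound 4 (0.03 log units; within the scatter) and leaves compound 2 and compound 4 without an order. The two lowest numbers therefore both carry a saturated chain carbon on the aromatic carbon, whereas cyclopentyl and cyclohexyl attach through a ring carbon.

From the compounds shown here alone, whether a longer chain such as pentyl or a methoxyethyl chain holds this level remains open. Nothing measured here explains these differences.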